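Working notes on a fused-ring series in HeLa cells

The compounds below may be only part of what the source reports. "The series", "measured", "known", "first", "only" and "open" are said of these compounds alone.

Measured so far:
compound 1 `COC(=O)C(C)n1n[n+]([O-])c2cc(C)c(C)cc21`: > 100 ug/mL
compound 2 `Cc1cc2c(cc1C)[n+]([O-])nn2C`: > 100 ug/mL
compound 3 `COC(=O)C(C)n1nc2c(n1)C(=O)C(C)=C(C)C2=O`: 0.9 ug/mL

All values come from a functional assay on HeLa cells (Homo sapiens) for inhibition, read by colorimetric assay, with a stated time of 72 h; a higher number here means that more compound is needed for the effect, a lower number that less compound is needed. For compound 1 the value > 100 ug/mL is a limit of the assay, not a number. For compound 2 the value > 100 ug/mL is likewise a limit. Among the compounds with values here, compound 3 gives 0.9 ug/mL, the only number in the set. The other two values sit at the limit of > 100 ug/mL in this assay, at which 2 of the 3 values shown sit.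

Compound 1 and compound 2 differ in one place, (methyl in place of 1-(methoxycarbonyl)ethyl on an aromatic nitrogen). Going by these compounds, the step that the two limits leave unreadable from compound 1 to compound 2 is left unreadable by the two limits, so its size is unknown. The difference between the core of compound 1 and the core of compound 3 is not broken down here.

Compound 4, `CC1=C(C)C(=O)c2nn(C)nc2C1=O`, is not yet measured in this assay. It differs from compound 3 by methyl in place of 1-(methoxycarbonyl)ethyl on an aromatic nitrogen. Within the data shown here, this is the same kind of change as the one from compound 1 to compound 2, but not the same: in compound 1 the place is next to the ring nitrogen, two ring bonds from the ring nitrogen and two ring bonds from the ring atom that bears a group of 1 heavy atom, whereas in compound 3 it is between two ring nitrogen atoms, two ring bonds from two ring atoms that each bear a fused ring.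

Among the measured compounds shown here, since the one measured precedent gives no readable size, the expectation rests on compound 3 alone and its value 0.9 ug/mL. A small step of a 2.2-fold higher number from compound 3 to compound 4 (0.35 log units; beyond the scatter) is expected, within or just beyond the usual scatter. Compound 4 is estimated at 2 ug/mL, with a likely range from 0.5 ug/mL to 8 ug/mL.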

Compound 4, concentration for half-maximal effect: 0.5 ug/mL
Compound 4: middle estimate off by 4.0-fold (0.60 log units), on the high side; the range from low to high includes it.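

In this assay, methyl in place of 1-(methoxycarbonyl)ethyl on the aromatic nitrogen of the core of compound 3 gives a 1.8-fold lower number from compound 3 to compound 4 (0.26 log units; within the scatter), so on this core the change leaves the two compounds indistinguishable, even though a group of six heavy atoms gives way to one of a single heavy atom. Compound 1 and compound 2 each stand at a limit of the assay rather than a number, so the step between them, the same kind of change on the other core, cannot be read: the limit of > 100 ug/mL in this assay, at which 2 of the 4 values shown sit. The series therefore holds one readable instance of this change, on one core, which shows nothing about whether the result carries from one core to another.

With only methyl and 1-(methoxycarbonyl)ethyl shown on this nitrogen, it remains open how a longer chain, a carboxylic acid or an amine at the same place would read on the core of compound 3. Also open is which part of the difference between the core of compound 1 and the core of compound 3 goes with their values, as that difference is not a single change and the compounds shown do not break it down.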